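Series notes: dimethylamino in place of phenoxy, compound 4

A few compounds are considered here, and "the series" means these few. Any claim that something is new, unique, unknown or untested is made for them only; others in the source may bear on it.

Measured so far in a functional assay on HCC 2998 cells (Homo sapiens) for cytotoxicity, read by sulforhodamine B assay, with a stated time of 48 h, tested at 10 uM; on this read-out lower numbers stand for a stronger effect and higher numbers for a weaker effect at the one concentration tested:
compound 1 `COc1cc(C)cc(-c2c(-c3ccnc(-c4ccc(C(C)=O)cc4)c3)cnn2CC#N)c1`: 5%
compound 2 `COc1cc(C)cc(-c2nn(CC#N)cc2-c2ccc(-c3cccc(C(C)=O)c3)nc2)c1`: -62%
compound 3 `Cc1cc(O)cc(-c2nn(CC#N)cc2-c2ccnc(-c3ccc(Oc4ccccc4)cc3)c2)c1`: -95%

On these three numbers compound 3 stands lowest. Its nearest neighbour is compound 2, whose number is higher by more than the scatter; compound 1 is the furthest, higher still and well beyond the scatter. No two of the measured compounds differ in a single place, so no change has yet been isolated in this assay.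

Compound 4 `Cc1cc(O)cc(-c2nn(CC#N)cc2-c2ccnc(-c3ccc(N(C)C)cc3)c2)c1` is not yet measured. Against compound 3 the difference is dimethylamino in place of phenoxy on an aromatic carbon. Going by the values given here, no measured pair shows this change, so the expectation rests on compound 3 alone. The step of a number 25 percentage points higher from compound 3 to compound 4 (beyond the scatter) is expected to be modest, in the direction of a weaker effect, and may well fall within the scatter. Compound 4 is estimated at -70%, with a range from -100% to -20%.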

Compound 4, a percentage reported as activity, at one concentration (the size of the read-out at that concentration, not a potency): -98%
Estimate against measurement, compound 4: 28 percentage points above; the range from low to high includes it.
By their numbers in this assay, from the lowest: compounds 4 and 3 (each within the scatter of the next); then compound 2; then compound 1.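

In this assay, dimethylamino in place of phenoxy on an aromatic carbon gives a number 3 percentage points lower from compound 3 to compound 4 (within the scatter) on the shared core. This first single-place pair shows that, for this pair, the read-out at this position holds without the six-membered aromatic ring of phenoxy and with a much smaller group in its place. No measured evidence accounts for this outcome. Still open, on these data alone, is whether a primary amine, a morpholine ring or a carboxylic acid at this place would hold the read-out as well. A single pair also leaves open whether the same exchange behaves alike on the core of compound 1 or compound 2.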